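From Compound 2 to Compound 4: One Ring for Another

The source may hold more compounds than are shown below. What is called first, only, known or untested is meant among the compounds shown, and "the series" means these compounds.

Measured compounds:
- compound 1, `O=C(NO)c1ccc(NCc2nc(-c3ccccc3)nn2-c2cccc(Cl)c2)cc1`: 62.3%
- compound 2, `Cc1ccc(-c2nc(CNc3ccc(C(=O)NO)cc3)n(-c3ccccc3)n2)cc1`: 62.2%
- compound 3, `O=C(NO)c1ccc(NCc2nc(-c3ccccc3)nn2-c2ccc(Cl)cc2)cc1`: 55.4%

Of the compounds shown here, three have been tested in an assay on Sf9 cells for inhibition of protein deacetylase HDAC6 (Homo sapiens), read by fluorescence, with a stated time of 40 min, tested at 100 nM; on this read-out lower numbers stand for less inhibition and higher numbers for more inhibition at the one concentration tested (going by the name of the read-out). Compound 2 stands second highest of the three numbers, but both gaps are within the scatter: compound 1 gives 62.3% and compound 3 gives 55.4%, so no order among the three can be read from these values. For the measured compounds named here, the only step between compounds that differ in one place, a number 6.9 percentage points lower from compound 1 to compound 3 (within the scatter), concerns the group on the aromatic nitrogen and is itself within the scatter.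

Compound 4, `O=C(NO)c1ccc(NCc2nc(-c3cc4ccccc4s3)nn2-c2ccccc2)cc1`, is not yet measured. It differs from compound 2 in one place: 1-benzothiophen-2-yl in place of 4-methylphenyl on an aromatic carbon. Going by the values given here, no measured step touches this position, since compounds 1 and 2 differ in two places at once. Among the compounds with values here, the one step that exists in this assay was flat, and nothing in the data indicates that this position moves the read-out. Compound 4 is therefore expected to lie near compound 2, with a step of a number 2.2 percentage points lower from compound 2 to compound 4 (within the scatter), no larger than the scatter. The estimate for compound 4 is 60%, ranging from 45% to 75%.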

Compound 4, a percentage reported as inhibition, at one concentration (the size of the read-out at that concentration, not a potency): 65.5%
Beside the measured number, compound 4's estimate is 5.5 percentage points below it; the measured number falls inside the stated range.
By their numbers in this assay, from the lowest: compounds 3, 2, 1 and 4 (each within the scatter of the next, the first and the last beyond it).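

For the compounds shown here, with this assay, the earlier compounds offered no step at this position, and the exchange of 4-methylphenyl for 1-benzothiophen-2-yl now supplies one: a number 3.3 percentage points higher from compound 2 to compound 4 (within the scatter). The group that enters has 9 heavy atoms against 7, adds a five-membered aromatic ring with 1 hetero atom to the six-membered aromatic ring of carbon only, and brings in sulfur, yet the read-out does not separate compound 4 from compound 2, so this carbon of the five-membered aromatic ring with 3 nitrogen accepts at least this one larger group without a change that stands out from the scatter. Nothing available here bears on why the two compounds read alike.

The compounds shown leave open whether an amine, a carboxylic acid or a longer chain on this same carbon would move the number beyond the scatter, as both groups seen here are aromatic and carry no net charge. The read-out also comes from a single concentration, which leaves open how compound 2 and compound 4 compare in potency.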